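The source may hold more compounds than are shown below. What is called first, only, known or untested is meant among the compounds shown, and "the series" means these compounds.

Three compounds have been measured so far in a functional assay on UO-31 cells (Homo sapiens) for antiproliferative activity, read by sulforhodamine B assay, with a stated time of 72 h; on this read-out lower numbers stand for stronger inhibition and higher numbers for weaker inhibition:

compound 1, `Clc1ccc(C(/C=C/c2ccccc2)=N\Nc2nncc3ccccc23)cc1`, 6.2 nM
compound 2, `NC(=S)NNc1nncc2ccccc12`, 33 nM
compound 3, `Cc1cc(NS(=O)(=O)c2ccc(Nc3nncc4ccccc34)cc2)no1`, 33 nM

In this assay compound 3 stands level with compound 2 at the digits shown, the two together giving the highest numbers of the three; the difference between them lies within the scatter. Among the measured compounds shown here, compound 1 gives a clearly lower number than compound 3, a gap beyond the scatter, but no single-point step connects these two structures, so only the two values themselves can be compared.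

The next compound, compound 4, `O=S(=O)(Nc1ccccn1)c1ccc(Nc2nncc3ccccc23)cc1`, is to be measured in this assay. It differs from compound 3 in one place: pyridin-2-yl in place of 5-methyl-1,2-oxazol-3-yl on a sulfonamide nitrogen. For the measured compounds named here, since no step between measured compounds is available to calibrate such an exchange, the expectation rests on compound 3 alone. A small step is expected a 1.1-fold lower number from compound 3 to compound 4 (0.04 log units; within the scatter), with no strong reason to expect a change beyond the scatter in either direction. Compound 4 is therefore expected to give about 30 nM, within a range from 10 nM to 100 nM.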

Compound 4, half-maximal inhibitory concentration: 44 nM
Compound 4: middle estimate off by 1.5-fold (0.17 log units), on the low side; the range from low to high includes it.
By their numbers in this assay, from the lowest: compound 1; then compounds 2, 3 and 4 (each within the scatter of the next).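

In this assay, among the compounds shown here, the exchange of 5-methyl-1,2-oxazol-3-yl for pyridin-2-yl on a sulfonamide nitrogen gives a 1.3-fold higher number from compound 3 to compound 4 (0.12 log units; within the scatter) and provides the first step that can be read at this position. With 6 heavy atoms in each group, a five-membered aromatic ring with 2 hetero atoms gives way to a six-membered aromatic ring with 1 hetero atom, and the assay does not separate the two compounds. Nothing measured here explains this result.

Both groups shown on this nitrogen are aromatic rings of equal heavy-atom count, so this one step says nothing about how far the position tolerates other kinds of group. Going by these compounds, it remains open whether a methyl group, a morpholine-bearing chain or a carboxylic acid on this sulfonamide nitrogen would give a number in the same range.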